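This account rests on a few compounds, and the source may have more. Where it says the series, first, only, none or still open, it means among the compounds named here.

Measured so far:
compound 1, `O=C(Nc1cccc(-n2cc(-c3ccncc3)c(-c3cc(O)cc(Cl)c3)n2)c1)Nc1ccc(Cl)c(Cl)c1`, giving 1440 nM in a functional assay on RPMI-8226 cells (Homo sapiens) for inhibition, read by sulforhodamine B assay, with a stated time of 48 h; a lower number here means a stronger inhibitor, a higher number a weaker inhibitor
compound 2, `COc1cc(Cl)cc(-c2nn(-c3cccc(NC(=O)Nc4ccc(Cl)c(Cl)c4)c3)cc2-c2ccncc2)c1`, giving 650 nM in this assay

Compound 2 holds the lower of these two numbers. Within the data shown here, the single measured step, a 2.2-fold lower number from compound 1 to compound 2 (0.35 log units; beyond the scatter), came from a methyl placed on an oxygen of one aromatic ring. Compound 3, `COc1cc(Cl)cc(-c2nn(-c3cccc(NC(=O)c4cccc(C(F)(F)F)c4)c3)cc2-c2ccncc2)c1`, differs from compound 2 at a different site: 3-(trifluoromethyl)phenyl in place of (3,4-dichlorophenyl)amino on a carbonyl carbon. Among the measured compounds shown here, no measured step touches the carbonyl end, so the size and direction of the change in this assay cannot be read from the two values shown, and the uncertainty is wide. Compound 3 is expected to give 1500 nM (range 350 nM to 6500 nM). That estimate means a step of a 2.3-fold higher number from compound 2 to compound 3 (0.36 log units; beyond the scatter).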

Compound 3, half-maximal inhibitory concentration: 3130 nM
Beside the measured number, compound 3's estimate is 2.1-fold (0.32 log units) below it; the range from low to high includes it.
By their numbers in this assay, from the lowest: compound 2; then compound 1; then compound 3.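

In this assay, 3-(trifluoromethyl)phenyl in place of (3,4-dichlorophenyl)amino on the carbonyl carbon gives a 4.8-fold higher number from compound 2 to compound 3 (0.68 log units; beyond the scatter), so the carbonyl end of the molecule does influence the number. This single swap changes two things at once: the amino nitrogen with its hydrogen-bond donor goes, and the ring carries different substituents. No measurement here explains the step. Which of the two changes matters remains open, and a (3-(trifluoromethyl)phenyl)amino group on the same carbonyl carbon would keep the nitrogen while changing only the ring.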